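This account rests on a few compounds, and the source may have more. Where it says the series, first, only, none or still open, it means among the compounds named here.

Working notes on a short series of diarylheptanoid-type compounds tested in a functional assay on RAW264.7 cells (Mus musculus) for inhibition, read by spectrophotometry and Griess assay, with a stated time of 24 h; a higher number here means a weaker inhibitor, a lower number a stronger inhibitor.

Compound 1 `COc1cc(CC[C@@H](O)C[C@@H](O)CCc2ccc(O)cc2)ccc1O` carries a methoxy on one aromatic ring and two secondary hydroxy groups in the chain; in this assay compound 1 gives 2810 nM. Compound 2 `COc1cc(CCC(=O)C[C@@H](O)CCc2ccc(O)cc2)ccc1O` keeps the methoxy but one hydroxy in the chain is replaced by a carbonyl; in this assay compound 2 gives 37500 nM. The difference between the two cores is not broken down here.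

Compound 3 `Oc1ccc(CC[C@@H](O)C[C@@H](O)CCc2ccc(O)cc2)cc1` is compound 1 with hydrogen in place of methoxy on an aromatic carbon. Compound 3 gives only a limit in this assay, > 100000 nM; this is the limit of > 100000 nM in this assay, at which 1 of the 3 values shown sits. The step is an at least 35-fold higher number from compound 1 to compound 3 (1.55 log units; beyond the scatter).

Compound 4 `O=C(CCc1ccc(O)cc1)C[C@@H](O)CCc1ccc(O)cc1` stands to compound 2 as compound 3 stands to compound 1, with hydrogen in place of methoxy on an aromatic carbon, the same change at the same place. Among the measured compounds shown here, the step from compound 2 to compound 4 is not yet measured; it is expected to be at least as large as the one seen for compound 1, an 11-fold higher number from compound 2 to compound 4 (1.03 log units; beyond the scatter), resting on an at least 35-fold higher number from compound 1 to compound 3 (1.55 log units; beyond the scatter). Starting from the number compound 2 gives, 37500 nM, the expectation for the new compound follows. Compound 4 is estimated at 400000 nM.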

Compound 4, half-maximal inhibitory concentration: 46400 nM
For compound 4 the middle estimate is 8.6-fold (0.94 log units) above the measured one; measured number below the stated range.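

Replacing methoxy with hydrogen on an aromatic carbon does not carry over at one size from one core to the other in this assay: the same change on two cores in this assay, an at least 35-fold higher number (1.55 log units; beyond the scatter) from compound 1 to compound 3 and a 1.2-fold higher number (0.09 log units; within the scatter) from compound 2 to compound 4, at least 28-fold (1.45 log units) apart, beyond the scatter of two such steps. On the core of compound 2, which has a carbonyl in the chain, the change gives a 1.2-fold higher number from compound 2 to compound 4 (0.09 log units; within the scatter), so the large step seen on the core of compound 1 cannot be assumed to transfer to this core. Among the compounds shown here, compound 3 stands at a limit rather than a number, and with only one pair on each core the series shows neither the full size of the first step nor which difference between the cores governs the outcome: the limit of > 100000 nM in this assay, at which 1 of the 4 values shown sits.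

The compounds shown leave open whether this dependence on the core also holds for other groups at the same place, such as ethoxy, fluorine or an amine. Also open, from the compounds shown here alone, is how the step behaves on a core with a longer chain or with carbonyl groups at both chain positions.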